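The compounds below may be only part of what the source reports. "The series", "measured", "known", "first", "only" and "open" are said of these compounds alone.

Compound 1 `CCCCCCCCCCNC(=O)[C@@H]1CSC(c2ccc(OC)c(OC)c2)N1` gives 6100 nM
Compound 2 `CCCCCCCCCCCCNC(=O)[C@@H]1CSC(c2ccc(NC(C)=O)cc2)N1` gives 1200 nM

In a functional assay on WM164 cells (Homo sapiens) for antiproliferative activity, read by sulforhodamine B assay, with a stated time of 48 h (on this read-out higher numbers stand for weaker inhibition and lower numbers for stronger inhibition), compound 2 stands lowest of the two measured compounds, and its gap to compound 1 lies beyond the usual scatter. These two compounds differ in more than one place, so their gap does not isolate any single change. Compound 3 `CCCCCCCCC/C=C\CCCCCCCNC(=O)[C@@H]1CSC(c2ccc(NC(C)=O)cc2)N1` keeps the rest of compound 2 and alters only the chain. The counted difference is a group of 11 heavy atoms (11 carbon; no ring) in place of a group of 5 heavy atoms (5 carbon; no ring), on a saturated chain carbon, seven bonds along the chain from an amide-type nitrogen here, with pentyl leaving and a group with one double bond entering on a saturated chain carbon, seven bonds along the chain from an amide-type nitrogen. Within the data shown here, no measured pair shows a chain change alone, so no step beyond the scatter is expected in this assay on this evidence. The expected step is a 1.2-fold lower number from compound 2 to compound 3 (0.08 log units; within the scatter) and would stay within the scatter. For compound 3 the estimated value is 1000 nM with an expected range from 350 nM to 3000 nM in this assay.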

Compound 3, half-maximal inhibitory concentration: 1000 nM
The estimate for compound 3 equals the measured number at the digits printed; the measured number falls inside the stated range.
By their numbers in this assay, from the lowest: compounds 3 and 2 (each within the scatter of the next); then compound 1.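

In this assay the place seven bonds along the chain from an amide-type nitrogen now has its first comparison that isolates a single change: pentyl gives way to a group of 11 heavy atoms with 1 double bond, and the step is a 1.2-fold lower number from compound 2 to compound 3 (0.08 log units; within the scatter). With the rest of compound 2 kept, this change in the chain therefore leaves a difference that cannot be told from the scatter, something the gap between compound 1 and compound 2 could not show, as those two differ in more than one place. No measurement here offers an explanation for this result.

The compounds shown leave open whether an amine or a carboxylic acid at the end of the chain would move the number beyond the scatter. They also leave open whether the same chain change would read alike on the core of compound 1.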